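From compound 2 to compound 3 in a cytotoxicity series

This account rests on a few compounds, and the source may have more. Where it says the series, first, only, none or still open, it means among the compounds named here.

Compound 1 `O=c1ccoc2cc(OCc3cn(Cc4ccccc4)nn3)ccc12`: > 100000 nM
Compound 2 `O=c1ccoc2cc(OCc3cn(Cc4cccc(Br)c4)nn3)ccc12`: > 100000 nM

In a functional assay on SGC-7901 cells (Homo sapiens) for cytotoxicity, read by MTT assay, with a stated time of 48 h (on this read-out higher numbers stand for weaker inhibition and lower numbers for stronger inhibition), compound 1 gives > 100000 nM, a limit of the assay rather than a number. In this assay compound 2 gives > 100000 nM, also a limit. The step that the two limits leave unreadable from compound 1 to compound 2 cannot be read, as both values sit at the limit of > 100000 nM in this assay, at which 2 of the 2 values shown sit. Compound 3 `Cc1ccccc1Cn1cc(COc2ccc3c(=O)ccoc3c2)nn1` differs from compound 2 by 2-methylphenyl in place of 3-bromophenyl on a saturated chain carbon bound to an aromatic nitrogen. Within the data shown here, the only measured step is unreadable, so no size or direction for the change in this assay can be drawn from it. Compound 3 is expected at 150000 nM, within 50000 nM to 500000 nM, most likely again a limit. The step from compound 2 to compound 3 is estimated as a step that the limit leaves unreadable from compound 2 to compound 3.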

Compound 3, half-maximal inhibitory concentration: > 100000 nM
Compound 3 ended at the assay's limit (the forecaster's own chance of this, stated with the estimate: 85%); the middle value lies beyond the limit too.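

Compound 3, like compound 1 and compound 2, stands at a limit in this assay, so no step among these compounds can be read. The compounds shown leave open whether any other group on the shared core would give a measurable value.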